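Benzyl-to-hydrogen change on two cores in a T47D series

A few compounds are considered here, and "the series" means these few. Any claim that something is new, unique, unknown or untested is made for them only; others in the source may bear on it.

Compound 1 `Cc1cc(C)c2nc(-c3cc4ccccc4n3Cc3ccccc3)[nH]c2c1` and compound 3 `Cc1cc(C)c2nc(-c3cc4ccccc4[nH]3)[nH]c2c1` share one core and differ by hydrogen in place of benzyl on an aromatic nitrogen. In a functional assay on T47D cells (Homo sapiens) for antiproliferative activity, read by MTT assay, with a stated time of 48 h (a higher number here means a weaker inhibitor, a lower number a stronger inhibitor), compound 1 gives 21800 nM, and compound 3 gives 24800 nM; the step is a 1.1-fold higher number from compound 1 to compound 3 (0.06 log units; within the scatter). The two values therefore cannot be separated here.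

Compound 2 `BrC1=CN2NC(c3cc4ccccc4n3Cc3ccccc3)=NC2N=C1` carries a second core; how the two cores differ is not broken down here. For compound 2 the entry in this assay reads "not determined" (no result reported), so no result was reported. Compound 4 `BrC1=CN2NC(c3cc4ccccc4[nH]3)=NC2N=C1` differs from compound 2 by hydrogen in place of benzyl on an aromatic nitrogen, the same change as from compound 1 to compound 3, since the two place descriptions agree word for word; the change appears in two pairs in all.

For compound 4 the expectation in this assay rests only on the first pair: the step from compound 1 to compound 3 was within the scatter, so a step of about the same size is expected for the second core, but with no value for compound 2 there is no anchor. Compound 4 is therefore estimated at about 22000 nM, with a wide expected range from 4000 nM to 90000 nM.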

Compound 4, half-maximal inhibitory concentration: 24400 nM
Compound 4: the middle estimate sits 1.1-fold (0.04 log units) below what was measured, and the stated range covers the measured number.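

Compound 2 has no number in this assay so the step from compound 2 to compound 4 cannot be read. The compounds shown leave open whether hydrogen in place of benzyl on the aromatic nitrogen gives a step of the same size on the core of compound 2 as on the core of compound 1. No accompanying data bear on this result.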